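From compound 2 to compound 3: one added methyl

The compounds below may be only part of what the source reports. "The series", "measured", "known", "first", "only" and "open" are said of these compounds alone.

Going by the values given here, in a functional assay on MCF7 cells (Homo sapiens) for antiproliferative activity, read by MTT assay, with a stated time of 72 h (on this read-out lower numbers stand for stronger inhibition and higher numbers for weaker inhibition), compound 2 (`C/C=C/C(=O)Nc1cccc(Oc2nc(Nc3cccc(OC)c3)nc3c2CSCC3)c1`) gives 23400 nM as the only exact number so far. Compound 1 (`CC/C=C/C(=O)Nc1cccc(Oc2nc(Nc3ccn(C)n3)nc3c2CSCC3)c1`) reports > 50000 nM as a limit and not a number. Compound 3 (`CC/C=C/C(=O)Nc1cccc(Oc2nc(Nc3cccc(OC)c3)nc3c2CSCC3)c1`) differs from compound 2 by one change (methyl in place of hydrogen on a saturated chain carbon bound to a double-bonded chain carbon), methyl in place of hydrogen on a saturated chain carbon bound to a double-bonded chain carbon. Among the compounds with values here, no measured pair tests this change, and no step beyond the scatter is expected for it in this assay on either side. The estimated step (a 1.1-fold higher number from compound 2 to compound 3 (0.03 log units; within the scatter)) reflects that expectation. Compound 3 is estimated at 25000 nM (expected range 10000 nM to 50000 nM).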

Compound 3, half-maximal inhibitory concentration: 24200 nM
Compound 3: middle estimate off by 1.0-fold (0.01 log units), on the high side; low and high end bracket the measured number.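

In this assay, going by these compounds alone, the added methyl that turns prop-1-en-1-yl into but-1-en-1-yl gives a 1.0-fold higher number from compound 2 to compound 3 (0.01 log units; within the scatter), so the first measured pair at this saturated chain carbon shows no change beyond the scatter. On a nitrogen on an aromatic ring, 3-methoxyphenyl in place of 1-methyl-1H-pyrazol-3-yl gives an at least 2.0-fold lower number from compound 1 to compound 3 (0.31 log units; beyond the scatter). That step is only a bound, as compound 1 carries a limit and not a number: the limit of > 50000 nM in this assay, at which 1 of the 3 values shown sits.

As far as these compounds go, whether an amine or a longer chain on this saturated chain carbon would move the number stays open. From the compounds shown here alone, the true size of the step on the nitrogen also stays open.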